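The source may report more compounds than this note shows. Statements on the series, on what has been measured and on what is new or still open speak of the compounds shown alone.

In a functional assay on KB cells (Homo sapiens) for cytotoxicity, read by MTT assay, with a stated time of 48 h (on this read-out lower numbers stand for stronger inhibition and higher numbers for weaker inhibition), compound 1 `CCn1cc(-c2nc3ccccc3o2)c(=O)c2cc(F)c(N3CCNC(C)C3)c(F)c21` gives 18900 nM. Compound 2 `CCn1cc(-c2nc3ccccc3o2)c(=O)c2cc(F)c(N3CCNCC3)nc21` gives 11700 nM in this assay, and compound 3 `CCn1cc(-c2nc3ccccc3s2)c(=O)c2cc(F)c(N3CCNCC3)nc21` gives 2400 nM. The difference between the core of compound 1 and the core of compound 2 is not broken down here. From compound 2 to compound 3 the change is 1,3-benzothiazol-2-yl in place of 1,3-benzoxazol-2-yl on an aromatic carbon, and it brought a 4.9-fold lower number from compound 2 to compound 3 (0.69 log units; beyond the scatter). Compound 4 `CCn1cc(-c2nc3ccccc3s2)c(=O)c2cc(F)c(N3CCNC(C)C3)c(F)c21` has not yet been measured; it differs from compound 1 by 1,3-benzothiazol-2-yl in place of 1,3-benzoxazol-2-yl on an aromatic carbon, the same change in the same surroundings, one that appears at two points among these compounds. Among the compounds with values here, a step of about a 4.7-fold lower number from compound 1 to compound 4 (0.67 log units; beyond the scatter) is expected, because compound 1 gives 18900 nM and the only precedent was a 4.9-fold lower number from compound 2 to compound 3 (0.69 log units; beyond the scatter), so the expectation rests on a single pair. Compound 4 is estimated at 4000 nM, between 1500 nM and 11000 nM.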

Compound 4, half-maximal inhibitory concentration: 24300 nM
The estimate for compound 4 lay 6.1-fold (0.78 log units) below the measured number; the measured number lies above the stated range.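

In this assay the exchange of 1,3-benzoxazol-2-yl for 1,3-benzothiazol-2-yl gave a 1.3-fold higher number from compound 1 to compound 4 (0.11 log units; within the scatter) and so made no difference beyond the scatter on the core of compound 1. Set beside the earlier step, the change did not carry over from one core to the other: the same change on two cores in this assay, a 4.9-fold lower number (0.69 log units; beyond the scatter) from compound 2 to compound 3 and a 1.3-fold higher number (0.11 log units; within the scatter) from compound 1 to compound 4, 6.3-fold (0.80 log units) apart, beyond the scatter of two such steps. This shows that its size depends on the surroundings in these two pairs, but it does not show which feature of the cores matters, and two pairs give no rule for any other core.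

The two cores differ in more than one place, and the compounds shown do not separate those differences. Also open, going by these compounds, is how a carboxylic acid in place of 1,3-benzothiazol-2-yl would read out on either core.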